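Removing a Chloro Group From an Inactive Starting Point

The source may hold more compounds than are shown below. What is called first, only, known or untested is meant among the compounds shown, and "the series" means these compounds.

Of the compounds shown here, two have so far been tested in a functional assay on SN12C cells (Homo sapiens) for antiproliferative activity, read by sulforhodamine B assay, with a stated time of 48 h; on this read-out higher numbers stand for weaker inhibition of growth and lower numbers for stronger inhibition of growth. Compound 1 `COc1ccc(OC)c(/C=C/c2nnc(Nc3ccc(Cl)cc3)o2)c1` gives > 100000 nM, which is a limit of the assay rather than a number. Compound 2 `COc1ccc(OC)c(/C=C/C(=O)N/N=C/c2ccc(Cl)cc2)c1` gives > 100000 nM, again only a limit. This matches (the limit of > 100000 nM in this assay, at which 2 of the 2 values shown sit). Compound 3 `COc1ccc(OC)c(/C=C/C(=O)N/N=C/c2ccccc2)c1` differs from compound 2 by hydrogen in place of chloro on an aromatic carbon. Within the data shown here, no measured step between two compounds exists to guide this change, so the expected step of a number no higher from compound 2 to compound 3 (the limit leaves the size open) is none beyond the usual scatter. Compound 3 is therefore estimated at 100000 nM, within 40000 nM to 300000 nM, most likely reported again only as a limit.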

Compound 3, concentration for total growth inhibition: 39900 nM
Compound 3: the middle estimate sits 2.5-fold (0.40 log units) above what was measured, outside the stated range (below it).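

In this assay, the change from 4-chlorophenyl to phenyl gives an at least 2.5-fold lower number from compound 2 to compound 3 (0.39 log units; beyond the scatter). This shows that the group at this position on the aromatic ring matters for growth inhibition, and that in this compound pair, chloro there is not needed for a measurable effect. The full size of the step stays unknown, since compound 2 has only a limit: the limit of > 100000 nM in this assay, at which 2 of the 3 values shown sit.

Going by these compounds, whether an amine or a carboxylic acid at this position would strengthen inhibition further remains open. So does whether the same change would help on the core of compound 1.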